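Aryl for Methyl on the Side Chain of a Styryl Sulfonamide

The source may hold more compounds than are shown below. What is called first, only, known or untested is meant among the compounds shown, and "the series" means these compounds.

Among the compounds with values here, compound 2 `COC(=O)C(C)Nc1cc(NS(=O)(=O)/C=C/c2c(OC)cc(OC)cc2OC)ccc1OC` gives 300 nM in a functional assay on K562 cells (Homo sapiens) for cytotoxicity, read by trypan blue exclusion, with a stated time of 96 h (on this read-out higher numbers stand for weaker inhibition and lower numbers for stronger inhibition), the highest of the two numbers measured so far. Within the data shown here, its nearest neighbour is compound 1 `COc1cc(OC)c(/C=C/S(=O)(=O)Nc2ccc(OC)c(OP(=O)(O)O)c2)c(OC)c1`, which in this assay gives 7.5 nM; the only measured step is a 40-fold higher number from compound 1 to compound 2 (1.60 log units; beyond the scatter). Compound 3 `COC(=O)C(Nc1cc(NS(=O)(=O)/C=C/c2c(OC)cc(OC)cc2OC)ccc1OC)c1ccc(F)cc1` differs from compound 2 by 4-fluorophenyl in place of methyl on a saturated chain carbon bound to a carbonyl carbon and a nitrogen on an aromatic ring. That single measured step alters a group on an aromatic carbon, a different place from the saturated chain carbon changed here, so it offers no direct guide. Compound 3 is therefore expected to stay close to compound 2, with a step of no change at the digits printed from compound 2 to compound 3 (within the scatter) expected to lie within the scatter. Compound 3 is estimated at 300 nM, within a range of 100 nM to 1000 nM.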

Compound 3, half-maximal inhibitory concentration: 2500 nM
Beside the measured number, compound 3's estimate is 8.3-fold (0.92 log units) below it; measured number outside the range, above it.
By their numbers in this assay, from the lowest: compound 1; then compound 2; then compound 3.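

At the saturated chain carbon bound to a carbonyl carbon and a nitrogen on an aromatic ring, the side chain is not indifferent: in this assay, 4-fluorophenyl in place of methyl gives an 8.3-fold higher number from compound 2 to compound 3 (0.92 log units; beyond the scatter), a weakening of inhibition. The earlier step changed only a group on an aromatic carbon and said nothing about this carbon. Nothing shown here accounts for this shift.

Going by these compounds, whether the ring or its fluorine carries the step stays open, as a plain phenyl would tell. Also open, on these data alone, is how a carboxylic acid in place of the methyl ester would read at this position.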